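Swapping the isopropylphenyl for a chlorosulfamoylphenyl

A few compounds are considered here, and "the series" means these few. Any claim that something is new, unique, unknown or untested is made for them only; others in the source may bear on it.

Measured compounds:
compound 1, `CCCS(=O)(=O)Nc1ccc(F)c(C(=O)c2n[nH]c3ncc(-c4ccccc4F)cc23)c1F`, 2%
compound 2, `CCCS(=O)(=O)Nc1ccc(F)c(C(=O)c2n[nH]c3ncc(-c4ccc(OC)cc4)cc23)c1F`, 4.2%
compound 3, `CCCS(=O)(=O)Nc1ccc(F)c(C(=O)c2n[nH]c3ncc(-c4ccc(C(C)C)cc4)cc23)c1F`, 17%

All three share one core and differ only in the aryl group attached to it. In an assay for binding affinity to dual specificity mitogen-activated protein kinase kinase 4 (Homo sapiens), read by KINOMEscan, tested at 100 nM (on this read-out higher numbers stand for a weaker effect at the one concentration tested and lower numbers for a stronger effect), compound 1 gives 2% and compound 2 gives 4.2%; the step of a number 2.2 percentage points higher from compound 1 to compound 2 (within the scatter) lies within the scatter. Compound 3 gives 17%, the highest of the three numbers, with a number 15 percentage points higher from compound 1 to compound 3 (beyond the scatter) and a number 12.8 percentage points higher from compound 2 to compound 3 (beyond the scatter) both beyond the scatter, so compound 3 is the weakest of the set at this concentration.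

Compound 4, `CCCS(=O)(=O)Nc1ccc(F)c(C(=O)c2n[nH]c3ncc(-c4ccc(S(N)(=O)=O)cc4Cl)cc23)c1F`, has not yet been measured. It differs from compound 3 by 2-chloro-4-sulfamoylphenyl in place of 4-isopropylphenyl on an aromatic carbon. Among the measured compounds shown here, the steps that bear on this are a number 12.8 percentage points higher from compound 2 to compound 3 (beyond the scatter) and a number 15 percentage points higher from compound 1 to compound 3 (beyond the scatter): replacing a 2-fluorophenyl or 4-methoxyphenyl with 4-isopropylphenyl raised the number modestly. Removing the isopropyl again, and bringing in a ring that carries a chlorine and a sulfamoyl group, is expected to move the number back down, by about a number 11 percentage points lower from compound 3 to compound 4 (beyond the scatter). For the measured compounds named here, no measured pair shows a sulfamoyl group, so the size is uncertain. The expected value for compound 4 is 6%, with a range of 1% to 20%.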

Compound 4, a percentage reported as activity, at one concentration (the size of the read-out at that concentration, not a potency): 3.4%
Estimate against measurement, compound 4: 2.6 percentage points above; the range from low to high includes it.
By their numbers in this assay, from the lowest: compounds 1, 4 and 2 (each within the scatter of the next); then compound 3.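

In this assay, the 2-chloro-4-sulfamoylphenyl ring gives a number 13.6 percentage points lower from compound 3 to compound 4 (beyond the scatter), so this aromatic carbon of the shared core can carry a ring with a sulfamoyl group, a hydrogen-bond donor and hydrogen-bond acceptors, and still give a low number at the one concentration tested. The new ring cannot be told apart from the two earlier rings that gave low numbers, with a number 0.8 percentage points lower from compound 2 to compound 4 (within the scatter) and a number 1.4 percentage points higher from compound 1 to compound 4 (within the scatter) both within the scatter, which leaves compound 3 as the only one of the four that stands apart, as the weakest at this concentration. Nothing given here accounts for these differences.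

On these data alone, the chlorine and the sulfamoyl group enter together, so their separate contributions stay unknown, and a 4-sulfamoylphenyl ring without chlorine or a 2-chlorophenyl ring would be needed to pull them apart. As far as these compounds go, it also remains open how the number responds to a ring carrying an amine or a carboxylic acid, and whether compounds this close at a single concentration would still match one another in a true potency measurement.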